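Acyl chain extension at the amide of compound 3

The source may hold more compounds than are shown below. What is called first, only, known or untested is meant among the compounds shown, and "the series" means these compounds.

Three compounds of the series have numbers in a functional assay on PC-3 cells (Homo sapiens) for antiproliferative activity, read by MTT assay, with a stated time of 72 h; a higher number here means a weaker inhibitor, a lower number a stronger inhibitor. Compound 1 `COc1cc2ncnc(N3CCc4ccccc43)c2cc1NC(=O)C=C(C)C` gives 7840 nM. Compound 2 `C=C(C)C(=O)Nc1cc2c(N3CCc4ccccc43)ncnc2cc1O[C@@H]1CCOC1` gives 4910 nM. Compound 3 `CC(C)=CC(=O)Nc1cc2c(N3CCc4ccccc43)ncnc2cc1O[C@@H]1CCOC1` gives 4620 nM; the steps of a 1.7-fold lower number from compound 1 to compound 3 (0.23 log units; within the scatter) and a 1.1-fold lower number from compound 2 to compound 3 (0.03 log units; within the scatter) both lie within the scatter, so on these numbers compound 3 stands alongside compounds 1 and 2 rather than apart from them. Compound 4 `CC(C)/C=C/C(=O)Nc1cc2c(N3CCc4ccccc43)ncnc2cc1O[C@@H]1CCOC1` has not been measured in this assay. It differs from compound 3 in one place: 3-methylbut-1-en-1-yl in place of 2-methylprop-1-en-1-yl on a carbonyl carbon. The step that bears on this change is the one at the same carbonyl carbon, a 1.1-fold lower number from compound 2 to compound 3 (0.03 log units; within the scatter), which was within the scatter; the other step, a 1.7-fold lower number from compound 1 to compound 3 (0.23 log units; within the scatter), concerns the oxygen on the aromatic ring and was also within the scatter. Nothing in the series shows a change at the carbonyl carbon moving the number beyond the scatter. The step expected from this change is a 1.0-fold lower number from compound 3 to compound 4 (0.01 log units; within the scatter), none beyond the scatter. Compound 4 is estimated at 4500 nM in this assay, with a range from 2000 nM to 10000 nM.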

Compound 4, half-maximal inhibitory concentration: 11200 nM
Compound 4: middle estimate off by 2.5-fold (0.40 log units), on the low side, and the stated range ends below it.
By their numbers in this assay, from the lowest: compounds 3, 2, 1 and 4 (each within the scatter of the next, the first and the last beyond it).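

At the carbonyl carbon of the amide, the series now shows change beyond the scatter in this assay: 3-methylbut-1-en-1-yl gives a weaker number than 2-methylprop-1-en-1-yl (a 2.4-fold higher number from compound 3 to compound 4 (0.38 log units; beyond the scatter)) and than 1-methylethenyl (a 2.3-fold higher number from compound 2 to compound 4 (0.36 log units; beyond the scatter)). The earlier exchange of 1-methylethenyl for 2-methylprop-1-en-1-yl stayed within the scatter, so this position does not tolerate every acyl change alike, though both new steps are modest. Nothing measured here accounts for the shift.

As far as these compounds go, whether a longer chain at this carbonyl carbon continues the rise, or an acyl group carrying an amine reverses it, remains open. Also open, from the compounds shown here alone, is whether the same step appears with methyl in place of oxolan-3-yl on the oxygen.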